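The source may report more compounds than this note shows. Statements on the series, on what has been measured and on what is new or still open speak of the compounds shown alone.

Compound 2 `Cc1nc(N)c2nn(Cc3ccccc3)cc2n1` gives 1% in an assay on CHO cells for displacement of a labelled ligand from adenosine receptor A3 (Homo sapiens), read by scintillation counting, with a stated time of 60 min, tested at 1 uM (on this read-out higher numbers stand for more inhibition at the one concentration tested (going by the name of the read-out) and lower numbers for less inhibition), the lowest of the three numbers recorded; compound 3 `Cn1cc2nc(CCCc3ccccc3)nc(N)c2n1` gives 30% and compound 1 `Nc1nc(-c2ccco2)nc2cn(-c3ccccc3O)nc12` gives 36%, both beyond the scatter above compound 2. Compound 4 `Nc1nc(-c2ccco2)nc2cn(Cc3ccccc3)nc12` differs from compound 2 by furan-2-yl in place of methyl on an aromatic carbon. Going by the values given here, no measured pair in this set isolates that change, but compound 1 carries furan-2-yl at the same place and gives 36%, so a rise beyond the scatter in this assay is the expectation. The step from compound 2 to compound 4 is expected to be a number 24 percentage points higher from compound 2 to compound 4 (beyond the scatter). Compound 4 is therefore estimated at 25%, within a range from 5% to 50%.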

Compound 4, a percentage reported as inhibition, at one concentration (the size of the read-out at that concentration, not a potency): 2%
Estimate against measurement, compound 4: 23 percentage points above; the measured number lies below the stated range.
By their numbers in this assay, from the lowest: compounds 2 and 4 (each within the scatter of the next); then compounds 3 and 1 (each within the scatter of the next).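

With benzyl on the aromatic nitrogen, a number 1 percentage points higher from compound 2 to compound 4 (within the scatter) in this assay for furan-2-yl in place of methyl, so on this aromatic carbon between two ring nitrogen atoms that change alone does not raise the read-out. With furan-2-yl held fixed, a number 34 percentage points lower from compound 1 to compound 4 (beyond the scatter) for benzyl in place of 2-hydroxyphenyl, which places the large difference at the substituent on the aromatic nitrogen. Nothing given here accounts for either step.

Going by these compounds, it remains open whether furan-2-yl would matter with 2-hydroxyphenyl on the nitrogen. On these data alone, it also remains open how an amine or a longer chain on the aromatic carbon would read.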